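The compounds below may be only part of what the source reports. "The series", "measured", "known", "first", "only" and "open" are said of these compounds alone.

Three compounds set the scene in a functional assay on MCF7 cells (Homo sapiens) for cytotoxicity, read by MTT assay, with a stated time of 48 h; a lower number here means a stronger inhibitor, a higher number a weaker inhibitor. Compound 1 `COc1ccc(-c2c[nH]c(=O)n2-c2cc(OC)c(OC)c(OC)c2)cc1OC` offers no number, and its entry reads "not determined" (no result reported). Compound 2 `COc1ccc(-c2c[nH]c(=O)n2-c2cc(OC)c(OC)c(OC)c2)cc1N` gives > 50000 nM, which is a limit of the assay and not a number. Compound 3 `COc1cc(-n2c(-c3ccccc3)cn(C(C)=O)c2=O)cc(OC)c1OC` gives > 50000 nM, which is likewise a limit and not a number. Compound 3 therefore has no exact value and stands at the limit of > 50000 nM in this assay, at which 2 of the 3 values shown sit.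

Compound 4 `COc1cc(-n2c(-c3ccc(Br)cc3)cn(C(C)=O)c2=O)cc(OC)c1OC` departs from compound 3 in a single place: bromo in place of hydrogen on an aromatic carbon. In words, this is bromo in place of hydrogen on an aromatic carbon, para to a large group, so that phenyl becomes 4-bromophenyl.

Among the measured compounds shown here, no measured pair shows what this change does in this assay, so the expectation stays cautious, with no shift beyond the usual scatter in either direction. The estimated step is an at least 1.2-fold lower number from compound 3 to compound 4 (0.09 log units; that floor lies within the scatter), and the assay may well report only a limit again. This expectation rests on compound 3, whose only reading is the limit > 50000 nM. Compound 4 is estimated at 40000 nM, with an expected range from 10000 nM to 100000 nM.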

Compound 4, half-maximal inhibitory concentration: 10600 nM
For compound 4 the middle estimate is 3.8-fold (0.58 log units) above the measured one; the measured number falls inside the stated range.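

Among the compounds shown, compound 4 is the only one with an exact reading in this assay, so this position on the phenyl, para to a large group, is the first place where a single change is seen to move the result off the limit. Bromo in place of hydrogen on this aromatic carbon gives an at least 4.7-fold lower number from compound 3 to compound 4 (0.67 log units; beyond the scatter), a step that compound 1 and compound 2 could not show, as neither forms a one-place pair with compound 3. The printed size is only a floor and the true step remains unknown, because the reading for compound 3 is a limit and not a number: the limit of > 50000 nM in this assay, at which 2 of the 4 values shown sit.

The compounds shown say nothing about chloro, methyl or an amine on the same aromatic carbon, so it remains open whether this shift belongs to bromo alone or would follow from other groups there. From the compounds shown here alone, it also remains open whether bromo on that carbon would do the same in a compound that carries a hydrogen in place of the acetyl group on the shared core.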